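The source may report more compounds than this note shows. Statements on the series, on what has been measured and on what is new or still open speak of the compounds shown alone.

Compound 1, with the structure `CCCCC[Se]c1nc([Se]CCCCC)c2cccnc2n1`, is the starting point. In a functional assay on HT-29 cells (Homo sapiens) for cytotoxicity, read by MTT assay, with a stated time of 72 h (a higher number here means a weaker inhibitor of growth, a lower number a stronger inhibitor of growth), compound 1 gives only a limit, > 100000 nM, and this is the limit of > 100000 nM in this assay, at which 1 of the 2 values shown sits. For the measured compounds named here, the only other measured compound, compound 2, has the structure `[SeH]c1nc(NCc2ccccc2)c2ccccc2n1` and a different core. In this assay compound 2 gives 62200 nM. Going by the values given here, no pair of measured compounds differs in a single place, so no measured step is available to show how large a single change can be in this setting.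

Compound 3, with the structure `CCCCC[Se]c1nc(N)c2cccnc2n1`, follows from compound 1 by one change: one nitrogen atom in place of a group of 6 heavy atoms (5 carbon, 1 selenium; no ring), on an aromatic carbon. With compound 1 at a limit, the size of any step cannot be read from the numbers, and there is no measured comparison to say whether an amino group at that position changes growth inhibition. The expected step from compound 1 to compound 3 is an at least 1.1-fold lower number from compound 1 to compound 3 (0.04 log units; that floor lies within the scatter), that is, none beyond the scatter. Compound 3 is therefore estimated at 90000 nM, with a range from 25000 nM to 300000 nM, and it may again return only a limit.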

Compound 3, concentration for 50% growth inhibition: 5910 nM
Beside the measured number, compound 3's estimate is 15-fold (1.18 log units) above it, outside the stated range (below it).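

In this assay, for the compounds shown here, putting amino in place of the group of 6 heavy atoms (5 carbon, 1 selenium) on this aromatic carbon gives an at least 16-fold lower number from compound 1 to compound 3 (1.22 log units; beyond the scatter), a large step and the first single change that can be read in this set. The position is therefore not indifferent to what it carries: one change at this place, with the rest of the core of compound 1 left as it stands, is enough for compound 3 to reach a measured value of 5910 nM. The printed size is only a floor and the true step may be larger, because compound 1 stands at a limit rather than at a number: the limit of > 100000 nM in this assay, at which 1 of the 3 values shown sits.

Since one group leaves and another enters in the same change, the compounds shown cannot say how much of the step comes from losing the selenium-bearing chain and how much from gaining amino. A methylamino group or a hydroxyl group at this position, or a shorter chain on the selenium that remains in compound 3, would be needed to separate these contributions and to show how narrow the preference at this place is.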